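The compounds below may be only part of what the source reports. "The series", "measured", "known", "first", "only" and "open" are said of these compounds alone.

Working notes on the ester variation in this dihydropyridine set. The compounds measured are compound 1 `CCO/C(O)=C1\C(C)=NC(C)=C([N+](=O)[O-])C1c1ccccn1`, compound 2 `COCCO/C(O)=C1\C(C)=NC(C)=C([N+](=O)[O-])C1c1ccncc1` and compound 3 `COCCO/C(O)=C1\C(C)=NC(C)=C([N+](=O)[O-])C1c1ccccn1`. In a functional assay (cardiac atrium) for agonist activity, with Cavia porcellus as the target (on this read-out lower numbers stand for an effect already at smaller amounts and higher numbers for an effect only at larger amounts of compound), compound 1 gives 22800 nM, compound 2 gives 37700 nM and compound 3 gives 9700 nM. Compound 2 thus stands at the highest of the three numbers, with compound 1 within the scatter of it and compound 3 beyond it, as the step of a 3.9-fold lower number from compound 2 to compound 3 (0.59 log units; beyond the scatter) shows. For the measured compounds named here, the step of a 2.4-fold lower number from compound 1 to compound 3 (0.37 log units; beyond the scatter) is the only measured change on the ester side and was modest. Compound 4 `CC1=NC(C)=C([N+](=O)[O-])C(c2ccncc2)/C1=C(\O)OC1CCCCC1` differs from compound 2 by cyclohexyl in place of 2-methoxyethyl on an oxygen on an unsaturated carbon. Going by the values given here, with only that one related step, a modest move toward higher numbers is expected, a 1.3-fold higher number from compound 2 to compound 4 (0.12 log units; within the scatter), giving compound 4 an estimated 50000 nM in this assay, in the range 15000 nM to 160000 nM.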

Compound 4, half-maximal effective concentration: 4940 nM
Compound 4: the middle estimate sits 10-fold (1.01 log units) above what was measured; the whole stated range lies above it.
By their numbers in this assay, from the lowest: compounds 4 and 3 (each within the scatter of the next); then compounds 1 and 2 (each within the scatter of the next).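

At the oxygen on an unsaturated carbon, a 7.6-fold lower number from compound 2 to compound 4 (0.88 log units; beyond the scatter) in this assay shows that this position tolerates a six-membered carbon ring, whereas the earlier ester step, a 2.4-fold lower number from compound 1 to compound 3 (0.37 log units; beyond the scatter), involved only open chains. With the pyridin-4-yl group, the lower number comes with cyclohexyl, which has no hydrogen-bond acceptor, so an acceptor in this group is not required for it. No supporting data on hand explain the step. Still open, going by these compounds, is whether cyclohexyl acts alike with pyridin-2-yl, and how a benzyl group or a longer chain would read at this oxygen.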